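A few compounds are considered here, and "the series" means these few. Any claim that something is new, unique, unknown or untested is made for them only; others in the source may bear on it.

Compounds measured so far:

Compound 1, `Cc1ccc(-n2nccn2)c(C(=O)N2CCC[C@@H]2Cn2ccc(-c3ccc(F)cn3)n2)c1`: 313 nM
Compound 2, `Cc1ccc(-n2nccn2)c(C(=O)N2CCC[C@H]2Cn2ccc(-c3ccc(F)cn3)n2)c1`: 3.15 nM
Compound 3, `Cc1ccc(-n2nccn2)c(C(=O)N2CCCC[C@@H]2Cn2ccc(-c3ccc(F)cn3)n2)c1`: 52.4 nM

All three were tested in a functional assay on CHO-K1 cells for antagonist activity at Orexin receptor type 2 (Homo sapiens), read by fluorescence and calcium flux, with a stated time of 30 min; a lower number here means a stronger inhibitor, a higher number a weaker inhibitor. Among them compound 3 gives 52.4 nM, the second highest of the three numbers: compound 1 sits above it and compound 2 well below it, both gaps beyond the scatter.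

The compound that follows is compound 4, `Cc1ccc(-n2nccn2)c(C(=O)N2CCCC[C@H]2Cn2ccc(-c3ccc(F)cn3)n2)c1`. Set against compound 3, (the two compounds have the same atoms and bonds and differ only in configuration as drawn: 1 of 1 stereo elements differ; a stereocentre at a saturated ring carbon is drawn R in compound 3 and S in compound 4). One measured step speaks directly to this kind of change: the step of a 99-fold lower number from compound 1 to compound 2 (2.00 log units; beyond the scatter), where the same ring carbon was redrawn from one configuration to the other and the number fell sharply. That step rests on (the fact that compounds 1 and 2 differ only in the configuration as drawn). Compound 3 and compound 4 stand in the same relation, on a ring that is one carbon larger, so a drop of similar direction is expected in this assay, though its size on the larger ring cannot be read from the numbers in hand. For compound 4 the expected result is therefore 5 nM, somewhere between 1 nM and 30 nM, which amounts to an estimated step of a 10-fold lower number from compound 3 to compound 4 (1.02 log units; beyond the scatter).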

Compound 4, half-maximal inhibitory concentration in the Orexin receptor type 2 assay: 1.64 nM
Compound 4: the middle estimate sits 3.0-fold (0.48 log units) above what was measured; measured number inside the range.
By their numbers in the Orexin receptor type 2 assay, from the lowest: compounds 4 and 2 (each within the scatter of the next); then compound 3; then compound 1.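

The preference for the configuration drawn S is not confined to the smaller ring: in the Orexin receptor type 2 assay it recurs on the ring one carbon larger, where compound 3 gives 52.4 nM and compound 4 gives 1.64 nM (a 32-fold lower number from compound 3 to compound 4 (1.50 log units; beyond the scatter)), a large step in the same direction as the earlier one (a 99-fold lower number from compound 1 to compound 2 (2.00 log units; beyond the scatter)), and the whole of it comes with the stereocentre alone: (the fact that compounds 3 and 4 differ only in the configuration as drawn). In a physicochemical assay for lipophilicity, read by HPLC, at pH 7.4 (a higher number here means a more lipophilic compound, a lower number a more polar compound), compound 3 gives 2.95 and compound 4 gives 2.96 with nothing beyond the scatter between them (a number 0.01 log units higher from compound 3 to compound 4 (within the scatter)), so this large step in receptor inhibition is not matched by any measurable difference in lipophilicity. With the S configuration, ring size is also no longer visible in the Orexin receptor type 2 assay where compound 2 gives 3.15 nM and compound 4 gives 1.64 nM (values within the scatter of each other).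

The compounds shown leave open whether this preference survives a change elsewhere on the shared core, such as a nitrile or an amine in place of the fluorine. They also do not tell why one configuration is favoured on both rings.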